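The compounds below may be only part of what the source reports. "The series", "measured", "known", "first", "only" and "open" are said of these compounds alone.

Of the compounds shown here, three have numbers so far in a functional assay (Homo sapiens) for inhibition; a lower number here means a stronger inhibitor, a higher number a weaker inhibitor. Compound 1 `CCCCCCc1cc(/C=C/C(=O)c2ccc(O)cc2)c(OC)cc1O` gives 46000 nM, compound 2 `O=C(/C=C/c1ccc(F)cc1)c1ccc(F)cc1` gives 22000 nM, and compound 3 `COc1ccc(C(=O)/C=C/c2ccccc2[N+](=O)[O-])c(OC)c1OC` gives 7000 nM. That makes compound 3 the strongest inhibitor of the three, and its gaps to both others lie beyond the usual scatter. These compounds differ in more than one place, so no clean single-change comparison is available to guide a forecast.

The next compound, compound 4 `COc1ccc(C(=O)/C=C/c2ccccc2O)c(OC)c1OC`, departs from compound 3 in one place: hydroxy in place of nitro on an aromatic carbon, ortho to a large group (hydroxy in place of nitro on an aromatic carbon). Nothing measured shows what this swap does. Still, compound 3, at 7000 nM, holds the lowest of the three numbers, so a new compound seems more likely to drift back toward the others than to go lower. The estimated change, a 2.1-fold higher number from compound 3 to compound 4 (0.33 log units; beyond the scatter), is toward weaker inhibition and modest in size. Compound 4 is expected at about 15000 nM, with an estimated range of 5000 nM to 45000 nM.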

Compound 4, half-maximal inhibitory concentration: 9000 nM
The estimate for compound 4 lay 1.7-fold (0.22 log units) above the measured number, within the range that was stated.
By their numbers in this assay, from the lowest: compounds 3 and 4 (each within the scatter of the next); then compound 2; then compound 1.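

In this assay, hydroxy in place of nitro on an aromatic carbon, ortho to a large group, gives a 1.3-fold higher number from compound 3 to compound 4 (0.11 log units; within the scatter). Among the compounds shown here, this is the first one-place comparison in the set, and it shows that this position can hold either group with no measurable difference in inhibition. The match comes despite a clear structural contrast: nitro has 3 heavy atoms and 0 hydrogen-bond donors, whereas hydroxy has 1 heavy atom and 1 hydrogen-bond donor, and no measurement shown here accounts for the match.

On these data alone, two groups cannot define what this position accepts, so the effect of an amine or a carboxylic acid on the same carbon remains unknown. Also unknown is whether the nitro-to-hydroxy swap would have as little effect on a different core, such as that of compound 1 or compound 2.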